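A Hydroxy-to-Ethyl Step Followed in Cytotoxicity Testing

This account rests on a few compounds, and the source may have more. Where it says the series, first, only, none or still open, it means among the compounds named here.

Compound 1, `O=c1[nH]c(=O)n([C@H]2C[C@H](O)[C@@H](CO)O2)cc1C#CCCO` — > 200000 nM
Compound 2, `Cc1ccc(S(=O)(=O)OCCC#Cc2cn([C@H]3C[C@H](O)[C@@H](CO)O3)c(=O)[nH]c2=O)cc1` — > 200000 nM
Compound 3, `Nc1ccn(C[C@@H]2C[C@H](CO)c3ccccc32)c(=O)n1` — > 200000 nM

In an ADME assay on L1210/0 cells (Mus musculus) for cytotoxicity, with a stated time of 48 h (on this read-out lower numbers stand for stronger inhibition and higher numbers for weaker inhibition), compound 1 gives > 200000 nM, which is a limit of the assay and not a number. Compound 2 also sits at a limit, > 200000 nM. Compound 3 sits at a limit as well, > 200000 nM. Compound 1 therefore stands at a limit, and so do both other measured compounds. Going by the values given here, the one step measured here, a step that the two limits leave unreadable from compound 1 to compound 2, is unreadable for that reason: the limit of > 200000 nM in this assay, at which 3 of the 3 values shown sit.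

Compound 4, `CCCCC#Cc1cn([C@H]2C[C@H](O)[C@@H](CO)O2)c(=O)[nH]c1=O`, differs from compound 1 by ethyl in place of hydroxy on a saturated chain carbon, two bonds along the chain from a triple-bonded carbon. Among the compounds with values here, no measured step bears on this change, and the single step recorded between compounds 1 and 2 gives no size in either direction. With every measured compound at the limit, the step of a number no higher from compound 1 to compound 4 (the limit leaves the size open) is expected to be unreadable in the same way. Compound 4 is therefore estimated at 200000 nM, within 50000 nM to 600000 nM, most likely as another limit.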

Compound 4, half-maximal inhibitory concentration: > 200000 nM
Compound 4 was reported as a limit (the forecaster's own chance of this, stated with the estimate: 75%); the middle value lies on the limit itself.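

No step can be read between compound 1 and compound 4, since each stands at a limit of the assay and not at a number: the limit of > 200000 nM in this assay, at which 4 of the 4 values shown sit.

The compounds shown leave open whether ethyl in place of hydroxy changes the result in this assay at all, and in which direction.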